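Notes on the step from compound 3 to compound 4

The source may report more compounds than this note shows. Statements on the series, on what has been measured and on what is new or still open speak of the compounds shown alone.

Measured so far in a functional assay on HepG2 cells (Homo sapiens) for antiproliferative activity, read by MTT assay, with a stated time of 48 h; on this read-out lower numbers stand for stronger inhibition and higher numbers for weaker inhibition:
- compound 1 `COc1ccc(-c2c(Nc3ccc(NC(C)=O)cc3)c3ccccc3oc2=O)cc1` gives > 100000 nM as a limit
- compound 2 `COc1ccc(-c2c(Nc3ccc(NC(C)=O)cc3)c3ccc(OC)cc3oc2=O)cc1` gives > 100000 nM as a limit
- compound 3 `COc1ccc(-c2c(Nc3ccc(C)c(O)c3)c3ccc(O)cc3oc2=O)cc1` gives > 75300 nM as a limit

Compound 3 stands at > 75300 nM as a limit and not a number. The series has no numerical reading so far, and two levels account for everything: the limit of > 100000 nM in this assay, at which 2 of the 3 values shown sit, and also the limit of > 75300 nM in this assay, at which 1 of the 3 values shown sits, as the other.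

The change from compound 3 to compound 4 `COc1ccc(-c2c(Nc3ccc(NC(C)=O)cc3)c3ccc(O)cc3oc2=O)cc1` is 4-acetamidophenyl in place of 3-hydroxy-4-methylphenyl on a nitrogen on an aromatic ring and puts 4-acetamidophenyl in place of 3-hydroxy-4-methylphenyl on a nitrogen on an aromatic ring. Among the compounds with values here, the only measured step is a step that the two limits leave unreadable from compound 1 to compound 2 and offers no size to carry over. The entering group also stands in compound 1, with > 100000 nM as a limit. It stands in compound 2 as well, with > 100000 nM as a limit.

No step beyond the scatter is expected in this assay, and another limit is the likeliest report. The estimated change is a step that the limit leaves unreadable from compound 3 to compound 4 in size. For compound 4 the expected value is 100000 nM with an estimated range of 40000 nM to 200000 nM as its ends.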

Compound 4, half-maximal inhibitory concentration: > 100000 nM
Compound 4 ended at the assay's limit; the forecaster's own chance of this, stated with the estimate: 75%; the middle value sits exactly at the limit.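

In this assay compound 4 gives > 100000 nM, which is a limit and not a number. The steps to compound 4 from compound 1, compound 2 and compound 3 therefore cannot be read. The compounds shown leave open what size any of these changes has, and which change on the shared core would give a numerical reading in this assay.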